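The source may report more compounds than this note shows. Statements on the series, on what has been measured and on what is new or still open speak of the compounds shown alone.

Measured in a functional assay on NCI-H460 cells (Homo sapiens) for inhibition, read by MTT assay, with a stated time of 72 h; a lower number here means a stronger inhibitor, a higher number a weaker inhibitor:
- compound 1 `COc1cc(NC(C)CCCNC(=O)Nc2cccc(Cl)c2)c2ncccc2c1`: 37000 nM
- compound 2 `COc1cc(NC(C)CCCNC(=O)Nc2cc(C(F)(F)F)cc(C(F)(F)F)c2)c2ncccc2c1`: 8300 nM

Compound 2, at 8300 nM, holds the lower of the two numbers, so it is the stronger inhibitor of the pair. Compound 1, at 37000 nM, lies beyond the usual scatter from it.

Compound 3 `COc1cc(NC(C)CCCNC(=O)Nc2cccc(C(F)(F)F)c2)c2ncccc2c1` is compound 2 with hydrogen in place of trifluoromethyl on an aromatic carbon, so one trifluoromethyl group remains. For the measured compounds named here, no measured pair differs in just one place, so this change has no direct precedent. Going by the values given here, the only hint is that compound 1, at 37000 nM, reads higher than compound 2, which carries two trifluoromethyl groups. A moderate rise in this assay is therefore expected, probably just beyond the scatter. The expected change is a 2.5-fold higher number from compound 2 to compound 3 (0.40 log units; beyond the scatter). For compound 3 the estimated value is 21000 nM, with an expected range of 9000 nM to 50000 nM.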

Compound 3, half-maximal inhibitory concentration: 21000 nM
The estimate for compound 3 equals the measured number at the digits printed; low and high end bracket the measured number.
By their numbers in this assay, from the lowest: compound 2; then compounds 3 and 1 (each within the scatter of the next).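

In this assay, for the compounds shown here, taking away one trifluoromethyl group from the aromatic ring of the urea side gives a 2.5-fold higher number from compound 2 to compound 3 (0.40 log units; beyond the scatter) and so isolates this change for the first time: the difference lies beyond the scatter, so this position, meta to the other trifluoromethyl group, does register in the assay, although the step is modest. Going by these compounds alone, the other single change gives a 1.8-fold lower number from compound 1 to compound 3 (0.25 log units; within the scatter) and stays within the scatter, so with only this one group on the ring, chloro and trifluoromethyl cannot be told apart here. The data offer no measurement that accounts for either step.

From the compounds shown here alone, it remains open whether only a second trifluoromethyl group gives this gain at that position, or whether a nitrile, an amine or a carboxylic acid there would do the same. Going by these compounds, how a longer chain between the core and the urea would affect these numbers also remains unknown.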